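Chain extension on two aryl sulfonate ester cores

A few compounds are considered here, and "the series" means these few. Any claim that something is new, unique, unknown or untested is made for them only; others in the source may bear on it.

Compound 1 `CCC(=O)Nc1ccc(S(=O)(=O)Oc2ccccc2I)cc1` and compound 2 `CCCC(=O)Nc1ccc(S(=O)(=O)Oc2ccccc2I)cc1` share one core; compound 3 `CCNC(=O)Nc1ccc(S(=O)(=O)Oc2ccccc2C(C)C)cc1` and compound 4 `CCCNC(=O)Nc1ccc(S(=O)(=O)Oc2ccccc2C(C)C)cc1` share another. The difference between the two cores is not broken down here. In a functional assay on HT-1080 cells (Homo sapiens) for antiproliferative activity, read by sulforhodamine B assay, with a stated time of 48 h (on this read-out higher numbers stand for weaker inhibition and lower numbers for stronger inhibition), compound 1 gives 7200 nM and compound 2 gives 2000 nM. The change from compound 1 to compound 2 is methyl in place of hydrogen on a saturated chain carbon, two bonds along the chain from a carbonyl carbon and it produced a step of a 3.6-fold lower number from compound 1 to compound 2 (0.56 log units; beyond the scatter). In this assay compound 3 gives 250 nM, the lowest number among the three measured compounds. Compound 4 has not been measured; it differs from compound 3 by methyl in place of hydrogen on a saturated chain carbon, two bonds along the chain from an amide-type nitrogen. This is the same kind of change as that from compound 1 to compound 2, but not the same: in the first pair the saturated chain carbon lies two bonds along the chain from a carbonyl carbon, in the second it lies two bonds along the chain from an amide-type nitrogen, and the core is different as well. Going by the values given here, the step from compound 3 to compound 4 in this assay is expected to be a 1.9-fold lower number from compound 3 to compound 4 (0.28 log units; within the scatter), somewhat smaller than the one precedent a 3.6-fold lower number from compound 1 to compound 2 (0.56 log units; beyond the scatter), since that precedent stands on another core and at a differently placed chain carbon. Compound 4 is therefore estimated at 130 nM in this assay, with an expected range from 50 nM to 400 nM.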

Compound 4, half-maximal inhibitory concentration: 680 nM
The estimate for compound 4 lay 5.2-fold (0.72 log units) below the measured number; the measured number lies above the stated range.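

In this assay the added methyl on the saturated chain carbon, two bonds along the chain from an amide-type nitrogen, gives a 2.7-fold higher number from compound 3 to compound 4 (0.43 log units; beyond the scatter) and so runs opposite to the step on the other core. Set side by side, the two steps disagree in direction and lie well apart: the same change on two cores in this assay, a 3.6-fold lower number (0.56 log units; beyond the scatter) from compound 1 to compound 2 and a 2.7-fold higher number (0.43 log units; beyond the scatter) from compound 3 to compound 4, 9.8-fold (0.99 log units) apart, beyond the scatter of two such steps. The gain from compound 1 to compound 2 therefore does not carry over to the core of compound 3, but these notes cannot say what accounts for this: the two pairs differ in the core and in the placing of the chain carbon, and each step rests on a single pair.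

Open, as far as these compounds go, is whether the propylamino chain on the core of compound 1, or the butanoyl chain on the core of compound 3, would separate the effect of the core from that of the chain's attachment. Also open, from the compounds shown here alone, is how a longer chain, such as butylamino, would read on the core of compound 3.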